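The compounds below may be only part of what the source reports. "The series", "measured", "known", "first", "only" and "open" are said of these compounds alone.

Of the compounds shown here, three that share one core have so far been measured in an assay on isolated protein for inhibition of histone deacetylase 8 (Homo sapiens), with a stated time of 1 h; on this read-out lower numbers stand for stronger inhibition and higher numbers for weaker inhibition. Compound 1 `COc1cccc(NC(=O)COc2ccc3cc(/C=C4/SC(=O)NC4=O)ccc3c2)c1` gives 7600 nM, and compound 2 `O=C(COc1ccc2cc(/C=C3/SC(=O)NC3=O)ccc2c1)Nc1ccc(F)cc1` gives 6600 nM. Compound 3 `Cc1ccc(NC(=O)COc2ccc3cc(/C=C4/SC(=O)NC4=O)ccc3c2)cc1Cl` gives only a limit of the assay, > 50000 nM, the same limit noted as the limit of > 50000 nM in this assay, at which 1 of the 3 values shown sits. The steps were an at least 6.5-fold higher number from compound 1 to compound 3 (0.81 log units; beyond the scatter) and an at least 7.5-fold higher number from compound 2 to compound 3 (0.87 log units; beyond the scatter), so compound 3 stands as the weakest of the three. Compound 4 `O=C(COc1ccc2cc(/C=C3/SC(=O)NC3=O)ccc2c1)Nc1cc(Cl)cc(C(F)(F)F)c1` has not yet been measured; its change is 3-chloro-5-(trifluoromethyl)phenyl in place of 3-chloro-4-methylphenyl on an amide-type nitrogen. Among the compounds with values here, no measured step trades one such aryl group for another carrying a trifluoromethyl, so the two steps that ended at compound 3 are the only guide, and both point to weak inhibition. In this assay the change is expected to amount to an at least 1.1-fold lower number from compound 3 to compound 4 (0.04 log units; that floor lies within the scatter), none beyond the scatter. Compound 4 is therefore expected to give about 45000 nM, within 9000 nM to 250000 nM.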

Compound 4, half-maximal inhibitory concentration: > 50000 nM
Compound 4 was reported as a limit; the forecaster's own chance of this, stated with the estimate: 60%; at least 1.1-fold (0.04 log units) between middle value and limit.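

Compound 4 reads only as a limit in this assay, the second compound on this read-out to do so: the limit of > 50000 nM in this assay, at which 2 of the 4 values shown sit.

The new aryl group on the amide-type nitrogen gives an at least 7.5-fold higher number from compound 2 to compound 4 (0.87 log units; beyond the scatter) and an at least 6.5-fold higher number from compound 1 to compound 4 (0.81 log units; beyond the scatter), so among these four compounds, both chlorine-bearing aryl groups lie beyond the scatter on the weak side of compounds 1 and 2. The step between compound 3 and compound 4 cannot be read, since both values are limits.

Going by these compounds, whether the chlorine itself matters remains open, as does how a phenyl ring carrying an amine or a carboxylic acid would read.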